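A few compounds are considered here, and "the series" means these few. Any claim that something is new, unique, unknown or untested is made for them only; others in the source may bear on it.

Measured so far:
Compound 1, `COc1ccc(-c2[nH]c3cc(Cl)c(C)cc3c2C=O)cc1`; in a functional assay on MCF7 cells (Homo sapiens) for antiproliferative activity, with a stated time of 5 days (on this read-out lower numbers stand for stronger inhibition and higher numbers for weaker inhibition), compound 1 gives 62 nM.
Compound 2, `COc1ccc(-c2[nH]c3ccc(C)cc3c2C=O)cc1`; in this assay compound 2 gives 140 nM.

Compound 2 stands at the highest of the two numbers. Within the data shown here, its nearest neighbour is compound 1, and the single measured step, a 2.3-fold higher number from compound 1 to compound 2 (0.35 log units; beyond the scatter), separates the two; that step lies beyond the scatter and consists of hydrogen in place of chloro on an aromatic carbon.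

Compound 3, `CCCCc1ccc2[nH]c(-c3ccc(OC)cc3)c(C=O)c2c1`, has not yet been measured in this assay. It differs from compound 2 in one place: propyl in place of hydrogen on a saturated chain carbon bound to an aromatic carbon. Cut one bond further out, the same change reads methyl to butyl.

Among the measured compounds shown here, no measured step touches this position or this kind of change. For the measured compounds named here, the one step that is known, a 2.3-fold higher number from compound 1 to compound 2 (0.35 log units; beyond the scatter), concerns a different substituent at a different site and offers no direct guide. With nothing pointing either way, the change is expected to give a step no larger than the scatter, a 1.1-fold higher number from compound 2 to compound 3 (0.03 log units; within the scatter). Going by the values given here, compound 3 is therefore estimated at 150 nM, within a range from 50 nM to 450 nM; the range is set wide, since no measured step bears on this change.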

Compound 3, half-maximal inhibitory concentration: 22 nM
Compound 3: middle estimate off by 6.8-fold (0.83 log units), on the high side, and the stated range ends above it.
By their numbers in this assay, from the lowest: compound 3; then compound 1; then compound 2.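

In this assay, lengthening the chain from methyl to butyl gives a 6.4-fold lower number from compound 2 to compound 3 (0.80 log units; beyond the scatter), the first sign that the number responds to a change at this place, on a saturated chain carbon bound to an aromatic carbon. Where the earlier compounds showed only what the chloro group did elsewhere on the shared core, with a 2.3-fold higher number from compound 1 to compound 2 (0.35 log units; beyond the scatter), they said nothing about the chain; the new step is the larger of the two, and both lie beyond the scatter. The data offer no measurement that could account for this step, so it stands as an observation alone.

As far as these compounds go, with only methyl and butyl at this place, it remains open how the number moves with chain length in between or beyond, whether through ethyl, a longer chain such as hexyl, or a branched chain such as tert-butyl. From the compounds shown here alone, it is also open whether the step depends on the chain being plain carbon, as a butyl chain ending in an amine or a carboxylic acid would test, and how a chloro group would act in one compound with the butyl chain.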